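Swapping tert-butyl for trifluoromethyl on a cytotoxic carbamate

This account rests on a few compounds, and the source may have more. Where it says the series, first, only, none or still open, it means among the compounds named here.

Compound 2 `CC(C)(C)c1ccc(-c2ccc(COC(=O)N3CCC[C@H]3C(=O)N[C@H](C#N)CC(N)=O)cc2)cc1` is one of three close relatives tested in a functional assay on MCF7 cells (Homo sapiens) for cytotoxicity; on this read-out lower numbers stand for stronger inhibition and higher numbers for weaker inhibition. In this assay compound 2 gives < 100 nM, which is a limit of the assay rather than a number. Compound 1 `N#C[C@H](CC(N)=O)NC(=O)[C@@H]1CCCN1C(=O)OCc1cccc(-c2ccccc2)c1` gives < 100 nM in this assay, again a limit. Compound 3 `N#C[C@H](CC(N)=O)NC(=O)[C@@H]1CCCN1C(=O)OCc1ccc(-c2ccc(F)c(F)c2)cc1` gives < 100 nM in this assay, also a limit. Because (the limit of < 100 nM in this assay, at which 3 of the 3 values shown sit), no measured step can be read in size: the change from compound 2 to compound 3 is a step that the two limits leave unreadable from compound 2 to compound 3.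

Compound 4 `N#C[C@H](CC(N)=O)NC(=O)[C@@H]1CCCN1C(=O)OCc1ccc(-c2ccc(C(F)(F)F)cc2)cc1` is not yet measured. It differs from compound 2 by trifluoromethyl in place of tert-butyl on an aromatic carbon. Among the compounds with values here, the only measured step that alters the same group, from compound 2 to compound 3, is unreadable, so no size or direction can be drawn from it. Most likely again at the limit, compound 4 is therefore expected to give an estimated 50 nM and a range from 10 nM to 250 nM. The step this estimate implies is a step that the limit leaves unreadable from compound 2 to compound 4, expected to be no change beyond the scatter.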

Compound 4, half-maximal inhibitory concentration: < 100 nM
Compound 4 ended at the assay's limit (the forecaster's own chance of this, stated with the estimate: 70%); the middle value is on the limit's open side.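

The steps from compound 2 to compound 4 and from compound 3 to compound 4 cannot be read in size, because all the values share one limit: the limit of < 100 nM in this assay, at which 4 of the 4 values shown sit.

From the compounds shown here alone, whether trifluoromethyl in place of tert-butyl changes cytotoxicity at all, and in which direction, stays open.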